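A few compounds are considered here, and "the series" means these few. Any claim that something is new, unique, unknown or untested is made for them only; others in the source may bear on it.

Three compounds built on one shared core have numbers in a functional assay on HCT-116 cells (Homo sapiens) for antiproliferative activity, read by sulforhodamine B assay, with a stated time of 48 h; on this read-out higher numbers stand for weaker inhibition and lower numbers for stronger inhibition. Compound 1 (`COc1cc(OC)c(C(=O)/C=C/c2ccc(OC)c(OC)c2)c(OCC=C(C)C)c1`) gives 5700 nM, compound 2 (`COc1ccc(/C=C/C(=O)c2c(OC)cc(OC)cc2OCC=C(C)C)cc1`) gives 7600 nM, and compound 3 (`COc1cc(OC)c(C(=O)/C=C/c2cccc(OC)c2OC)c(OCC=C(C)C)c1`) gives 11700 nM. Two measured steps show where that last value stands: a 1.5-fold higher number from compound 2 to compound 3 (0.19 log units; within the scatter), and a 2.1-fold higher number from compound 1 to compound 3 (0.31 log units; beyond the scatter).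

Compound 4 (`COc1cc(OC)c(C(=O)/C=C/c2cc(Cl)cc(Cl)c2)c(OCC=C(C)C)c1`) has not yet been measured. Compared with compound 3, it has 3,5-dichlorophenyl in place of 2,3-dimethoxyphenyl on a double-bonded chain carbon bound to a double-bonded chain carbon.

All three measured steps bear on this change, since each alters the aromatic group at that same place. Besides the two above, there is a 1.3-fold higher number from compound 1 to compound 2 (0.12 log units; within the scatter). Only one of the three passes the scatter, and it is modest. Among the compounds with values here, none of the measured compounds carries chlorine, however, so these steps offer only indirect guidance and the range must stay wide.

No step beyond the scatter is therefore expected in this assay. The estimated change is a 1.5-fold lower number from compound 3 to compound 4 (0.17 log units; within the scatter), a shift that would stay within the scatter. Compound 4 is estimated at 8000 nM, with an expected range from 3000 nM to 20000 nM.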

Compound 4, half-maximal inhibitory concentration: 24500 nM
Compound 4: the middle estimate sits 3.1-fold (0.49 log units) below what was measured; the whole stated range lies below it.
By their numbers in this assay, from the lowest: compounds 1, 2 and 3 (each within the scatter of the next, the first and the last beyond it); then compound 4.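

In this assay, compound 4 gives the weakest inhibition of the four compounds, and each step to it lies beyond the scatter (a 2.1-fold higher number from compound 3 to compound 4 (0.32 log units; beyond the scatter); a 3.2-fold higher number from compound 2 to compound 4 (0.51 log units; beyond the scatter); a 4.3-fold higher number from compound 1 to compound 4 (0.63 log units; beyond the scatter)). The earlier compounds shown here carried only methoxy-bearing phenyl groups on the double-bonded chain carbon and moved the number only a little, whereas 3,5-dichlorophenyl at this same place gives the highest number so far, although each of these steps is still modest. Nothing measured here gives a cause for this shift.

Within the data shown here, with only one chlorine-bearing group in the set, the compounds leave open whether the higher number goes with the chlorine atoms themselves, with their arrangement as 3,5-dichlorophenyl, or simply with the absence of methoxy groups. An unsubstituted phenyl group, a phenyl group with a single chlorine, or a phenyl group bearing a hydroxyl, an amine or a carboxylic acid at this place would help to separate these possibilities.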